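Swapping Sulfamoyl for Methylpiperazinyl on a Shared Core

The source may hold more compounds than are shown below. What is called first, only, known or untested is meant among the compounds shown, and "the series" means these compounds.

Measured compounds:
compound 1, `NS(=O)(=O)c1cccc(Nc2nccc(Nc3ccc4nc[nH]c4c3)n2)c1` — > 25000 nM
compound 2, `O=C(O)c1ccc(Nc2nccc(Nc3ccc4nc[nH]c4c3)n2)cc1` — > 25000 nM
compound 3, `Cc1ccc(Nc2nccc(Nc3ccc4cn[nH]c4c3)n2)cc1` — 18000 nM

In an ADME assay on HepG2 cells (Homo sapiens) for inhibition, read by fluorescence and resazurin assay, with a stated time of 72 h (a higher number here means a weaker inhibitor, a lower number a stronger inhibitor), compound 1 gives > 25000 nM, which is a limit of the assay and not a number. Compound 2 also reaches only a limit in this assay, > 25000 nM. Among the measured compounds shown here, compound 3 is the one compound with a number in this assay, giving 18000 nM. Compound 1 therefore stands at the limit of > 25000 nM in this assay, at which 2 of the 3 values shown sit; nothing more than that can be said of where it lies, and no ordering of the three compounds is offered.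

The next compound, compound 4, `CN1CCN(c2cccc(Nc3nccc(Nc4ccc5nc[nH]c5c4)n3)c2)CC1`, differs from compound 1 in a single place: 4-methylpiperazin-1-yl in place of sulfamoyl on an aromatic carbon.

For the measured compounds named here, no measured pair in this set differs in only one place, so the size of such a change has no precedent here. Because compound 1 sits at the limit of > 25000 nM in this assay, at which 2 of the 3 values shown sit, the starting point is itself uncertain. For compound 4 a modest step toward stronger inhibition, near the edge of the usual scatter, is expected, and the step that this expectation implies is an at least 2.0-fold lower number from compound 1 to compound 4 (0.31 log units; beyond the scatter). Compound 4 is thus estimated at 12000 nM, with a range from 4000 nM to 30000 nM.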

Compound 4, half-maximal inhibitory concentration: 11000 nM
Estimate against measurement, compound 4: 1.1-fold (0.04 log units) above; measured number inside the range.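

In this assay, among the compounds shown here, placing 4-methylpiperazin-1-yl where sulfamoyl stood gives an at least 2.2-fold lower number from compound 1 to compound 4 (0.35 log units; beyond the scatter), the first step in this set between two compounds that differ in one place, and it lies beyond the scatter. It shows that this place, an aromatic carbon meta to a large group, can change the read-out on the shared core: compound 4 has a number here, whereas compound 1 reached only a limit of the assay. The true size of the step stays open at one end, because its starting point is a limit and not a number: the limit of > 25000 nM in this assay, at which 2 of the 4 values shown sit.

The compounds shown leave open whether the six-membered ring of 4-methylpiperazin-1-yl or its methyl group accounts for the step, since neither a piperazine without the methyl group nor a morpholine ring stands at this place among them. They also leave open whether a smaller group here, such as a primary amine or a methoxy group, would give a number at all, and whether the same swap would give a step of similar size on the core of compound 3.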